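Swapping a fluorophenyl for a fluoropyridyl on the shared core

The source may hold more compounds than are shown below. What is called first, only, known or untested is meant among the compounds shown, and "the series" means these compounds.

Measured compounds:
compound 1 `CN(C)c1ccc2cc(-c3ccccc3F)c(N)nc2c1`, 1600 nM
compound 2 `CN(C)c1ccc2cc(-c3ccc(Cl)c(Cl)c3)c(N)nc2c1`, 3200 nM
compound 3 `CN(C)c1ccc2cc(-c3nccn3C)c(N)nc2c1`, "not determined" (no result reported)

The series was examined in a toxicity assay on J774.A1 cells (Mus musculus) for cytotoxicity, read by SYBR Green assay, with a stated time of 1 h; on this read-out higher numbers stand for an effect only at larger amounts of compound and lower numbers for an effect already at smaller amounts. Compound 1 gives 1600 nM. Compound 2 gives 3200 nM. Among the measured compounds shown here, only two numbers exist, and the gap between compound 1 and compound 2 lies within the usual scatter of repeated measurements, so neither compound can be set apart from the other on this read-out. Compound 3 gives "not determined" (no result reported), so nothing can be said of it.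

The unmeasured compound 4 `CN(C)c1ccc2cc(-c3ncccc3F)c(N)nc2c1` differs from compound 1 in one place: 3-fluoropyridin-2-yl in place of 2-fluorophenyl on an aromatic carbon. The two groups that leave and enter are the same size, and the change is confined to this aromatic carbon of the shared core.

For the measured compounds named here, no step between measured compounds is known for this change. Given that the only two numbers in hand, those of compound 1 and compound 2, lie within the scatter of each other, no step beyond the scatter is expected from compound 1 to compound 4 in this assay. Compound 4 is therefore expected to give 2000 nM, with a range from 800 nM to 5000 nM. The estimated step of a 1.3-fold higher number from compound 1 to compound 4 (0.10 log units; within the scatter) is expected to fall within the scatter.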

Compound 4, half-maximal effective concentration: 16000 nM
The estimate for compound 4 lay 8.0-fold (0.90 log units) below the measured number; the whole stated range lies below it.
By their numbers in this assay, from the lowest: compounds 1 and 2 (each within the scatter of the next); then compound 4.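

In this assay, putting 3-fluoropyridin-2-yl in place of 2-fluorophenyl gives a 10-fold higher number from compound 1 to compound 4 (1.00 log units; beyond the scatter), so compound 4 shows its effect only at larger amounts than compound 1 does. Among the compounds shown here, this is the only step that can be read at this position, on an aromatic carbon ortho to an amino group and two atoms from the ring nitrogen, and it shows that the read-out responds here to a change that leaves the heavy-atom count as it was: a ring of carbon only gives way to a ring with 1 hetero atom, and the entering group carries 1 hydrogen-bond acceptor where the leaving group carries none. Nothing in hand explains the step.

The compounds shown leave open whether the step belongs to the ring nitrogen alone or to the ring nitrogen together with the fluorine, which a plain pyridin-2-yl group on the same carbon would help to settle. For the compounds shown here, also open is how a pyridin-3-yl or a pyrimidin-2-yl group would compare, since compound 3, the only other compound here with a hetero atom in this ring, has no number.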